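The compounds below may be only part of what the source reports. "The series", "measured", "known", "first", "only" and "open" are said of these compounds alone.

Working notes on the series, read in a functional assay on A549 cells (Homo sapiens) for cytotoxicity, read by MTT assay, with a stated time of 72 h; a lower number here means a stronger inhibitor, a higher number a weaker inhibitor. Compound 1 `O=C(N/N=C/c1cccc(Br)c1)Nc1cc2c(Nc3ccc(F)c(Cl)c3)ncnc2cc1O[C@H]1CCOC1` gives 10700 nM, compound 2 `O=C(N/N=C/c1ccc([N+](=O)[O-])cc1)Nc1cc2c(Nc3ccc(F)c(Cl)c3)ncnc2cc1O[C@H]1CCOC1` gives 31200 nM and compound 3 `COc1cc2ncnc(Nc3ccc(F)c(Cl)c3)c2cc1NC(=O)N/N=C/c1cccc(Br)c1` gives 28100 nM. The values of compound 3 and compound 2 lie within the scatter of each other, and both are weaker than compound 1. The gap to compound 3 is a 2.6-fold higher number from compound 1 to compound 3 (0.42 log units; beyond the scatter), a modest step that swaps methyl for oxolan-3-yl on an oxygen on an aromatic ring.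

Compound 4 `COc1cc2ncnc(Nc3ccc(F)c(Cl)c3)c2cc1NC(=O)N/N=C/c1ccc([N+](=O)[O-])cc1` differs from compound 3 in one place, with 4-nitrophenyl in place of 3-bromophenyl on a carbon with a double bond to nitrogen. The same exchange has been measured once, as a 2.9-fold higher number from compound 1 to compound 2 (0.46 log units; beyond the scatter), also modest and beyond the scatter. Going by the values given here, that single pair is the only direct precedent, and it carries the oxolan-3-yl group rather than methyl, so a modest step to a higher number is expected, perhaps slightly smaller. The estimated change is a 2.3-fold higher number from compound 3 to compound 4 (0.36 log units; beyond the scatter). The estimate for compound 4 is 65000 nM, with an expected range of 28000 nM to 140000 nM.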

Compound 4, half-maximal inhibitory concentration: 35100 nM
The estimate for compound 4 lay 1.9-fold (0.27 log units) above the measured number, and the stated range covers the measured number.
By their numbers in this assay, from the lowest: compound 1; then compounds 3, 2 and 4 (each within the scatter of the next).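

With methyl on the oxygen, neither exchange clears the scatter in this assay: 4-nitrophenyl in place of 3-bromophenyl gives a 1.2-fold higher number from compound 3 to compound 4 (0.10 log units; within the scatter), and methyl in place of oxolan-3-yl, with 4-nitrophenyl present, gives a 1.1-fold higher number from compound 2 to compound 4 (0.05 log units; within the scatter). The step seen for the aryl exchange with oxolan-3-yl present therefore does not recur as a resolved step, yet the two readings cannot be told apart: the same change on two cores in this assay, a 2.9-fold higher number (0.46 log units; beyond the scatter) from compound 1 to compound 2 and a 1.2-fold higher number (0.10 log units; within the scatter) from compound 3 to compound 4, 2.3-fold (0.37 log units) apart, within the scatter of two such steps The same holds for the exchange on the oxygen, so no dependence of one place on the other is shown: the same change on two cores in this assay, a 2.6-fold higher number (0.42 log units; beyond the scatter) from compound 1 to compound 3 and a 1.1-fold higher number (0.05 log units; within the scatter) from compound 2 to compound 4, 2.3-fold (0.37 log units) apart, within the scatter of two such steps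

Going by these compounds alone, with only two groups at each place, the series says little about how far either place can move the number. Open, as far as these compounds go, are a 4-aminophenyl group on the carbon with a double bond to nitrogen, a carboxylic acid on that phenyl ring, and a longer chain such as 2-methoxyethyl on the oxygen.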